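Shortening the Nitrogen-Bound Chain and Expected Cytotoxicity

The compounds below may be only part of what the source reports. "The series", "measured", "known", "first", "only" and "open" are said of these compounds alone.

Measured so far in an ADME assay on Huh-7 cells (Homo sapiens) for cytotoxicity, with a stated time of 72 h; a lower number here means that less compound is tolerated, a higher number that more compound is tolerated:
- compound 1 `CC(C)CCn1nc(-c2cccs2)c(O)c(C2=NS(=O)(=O)c3cc(N(C(C)C)S(C)(=O)=O)ccc3N2)c1=O` gives "not determined" (no result reported).
- compound 2 `CC(C)CCn1nc(C2CCCCC2)c(O)c(C2=NS(=O)(=O)c3cc(NS(C)(=O)=O)ccc3N2)c1=O` gives > 1000 nM, which is a limit of the assay and not a number.
- compound 3 `CC(C)(C)CCn1nc(-c2cccs2)c(O)c(C2=NS(=O)(=O)c3cc(NS(C)(=O)=O)ccc3N2)c1=O` gives > 1000 nM, again a limit of the assay rather than a number.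

Compound 3 therefore stands at the edge of what this assay reports: its value is a limit, compound 2 sits at the same limit, and compound 1 has no result at all. For the measured compounds named here, the only thing the measured set shows is the limit of > 1000 nM in this assay, at which 2 of the 3 values shown sit, so there is no measured step to lean on.

The unmeasured compound 4 `CCC(C)n1nc(-c2cccs2)c(O)c(C2=NS(=O)(=O)c3cc(NS(C)(=O)=O)ccc3N2)c1=O` differs from compound 3 in one place: sec-butyl in place of 3,3-dimethylbutyl on an aromatic nitrogen. The change is small and keeps the rest of the shared core untouched.

With both numbered neighbours at the limit, no step beyond the usual scatter is expected; the estimated step from compound 3 to compound 4 is a step that the limit leaves unreadable from compound 3 to compound 4. Compound 4 is expected to give about 3000 nM, within a range of 1000 nM to 20000 nM, most likely reported again as a limit in this assay.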

Compound 4, half-maximal cytotoxic concentration: > 33000 nM
Compound 4 was reported as a limit; the forecaster's own chance of this, stated with the estimate: 80%; middle value at least 11-fold (1.04 log units) away from the limit.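

In this assay, compound 3 and compound 4 are each reported only as a limit of the assay, so the size of the step from 3,3-dimethylbutyl to sec-butyl cannot be read. The compounds shown leave open the concentration at which any of them harms the cells in this assay, and whether this chain affects it.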